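This account rests on a few compounds, and the source may have more. Where it says the series, first, only, none or still open, it means among the compounds named here.

Measured so far:
compound 1 `CCOC(=O)C1=Cc2ccccc2OC1(OCc1cc(-c2ccc3ccccc3c2)no1)C(F)(F)F` — > 150000 nM in a functional assay on HeLa cells (Homo sapiens) for inhibition, read by MTT assay, with a stated time of 24 h; a higher number here means a weaker inhibitor, a lower number a stronger inhibitor
compound 2 `Cc1ccc(-c2cc(COC3(C(F)(F)F)Oc4ccccc4C=C3C(=O)O)on2)cc1` — 33400 nM
compound 3 `O=C(O)C1=Cc2ccccc2OC1(OCc1cc(-c2ccc([N+](=O)[O-])cc2)no1)C(F)(F)F` — > 150000 nM

Compound 1 gives only a limit in this assay, > 150000 nM. Compound 2 gives a number, 33400 nM. Compound 3 again gives only a limit, > 150000 nM. Compound 3 thus stands at the limit of > 150000 nM in this assay, at which 2 of the 3 values shown sit, with no number of its own; only compound 2 gives a value inside the range of the assay.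

Compound 4 `O=C(O)C1=Cc2ccccc2OC1(OCc1cc(-c2ccc3ccccc3c2)no1)C(F)(F)F` is the next member: naphthalen-2-yl in place of 4-nitrophenyl on an aromatic carbon. Among the measured compounds shown here, one measured step touches that carbon. There, an at least 4.4-fold higher number from compound 2 to compound 3 (0.65 log units; beyond the scatter), so replacing the methyl-bearing ring with the nitro-bearing one weakened inhibition at least modestly. The new change removes the nitro group and brings in naphthalen-2-yl instead of 4-nitrophenyl. Compound 1, which already carries naphthalen-2-yl and differs from compound 4 in one place elsewhere on the shared core, sits at the limit too, which gives little hope of a large gain. The expectation is therefore a step from the limit toward a weak but measurable number at most, or none beyond the scatter. Compound 4 is expected near 100000 nM, within 20000 nM to 300000 nM. That estimate means an expected step of an at least 1.5-fold lower number from compound 3 to compound 4 (0.17 log units; that floor lies within the scatter).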

Compound 4, half-maximal inhibitory concentration: > 150000 nM
Compound 4 was reported as a limit; the forecaster's own chance of this, stated with the estimate: 55%; at least 1.5-fold (0.17 log units) between middle value and limit.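

At the aromatic carbon next to the ring nitrogen, naphthalen-2-yl in place of 4-methylphenyl gives an at least 4.4-fold higher number from compound 2 to compound 4 (0.65 log units; beyond the scatter) in this assay, so a second aryl group at this position, and this time one without a nitro group, fails to keep a value inside the range of the assay. The pair of compound 1 and compound 4 adds something new: with naphthalen-2-yl in place, hydrogen instead of ethyl on the oxygen next to a carbonyl group still yields no number, although the steps from compound 3 to compound 4 and from compound 1 to compound 4 cannot be read, as both ends of each are limits. Among the compounds shown, only compound 2, with 4-methylphenyl, now stands apart from the rest: the limit of > 150000 nM in this assay, at which 3 of the 4 values shown sit.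

The compounds shown leave open how a plain phenyl, a 4-chlorophenyl or a 4-methoxyphenyl group would read at this carbon, and so whether the value of compound 2 depends on the methyl group itself. Also open, from the compounds shown here alone, are what an ethyl ester would do alongside 4-methylphenyl and how far compound 1, compound 3 and compound 4 lie past their limits.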